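The compounds below may be only part of what the source reports. "The series", "measured", "known", "first", "only" and "open" are said of these compounds alone.

Measured so far in a functional assay on MIA PaCa-2 cells (Homo sapiens) for inhibition, read by MTT assay, with a stated time of 7 days; a lower number here means a stronger inhibitor, a higher number a weaker inhibitor:
compound 1 `CCN(CC)S(=O)(=O)c1ccc(S(=O)(=O)N2CCC[C@@H](C(=O)N3CCC(O)CC3)C2)cc1` gives 870 nM;
compound 2 `CC(C)S(=O)(=O)c1ccc(S(=O)(=O)N2CCC[C@@H](C(=O)N3CCC(F)(F)CC3)C2)cc1` gives 11 nM;
compound 3 `CCN(CC)S(=O)(=O)c1ccc(S(=O)(=O)N2CCC[C@@H](C(=O)N[C@H]3CC[C@@H](OC)CC3)C2)cc1` gives 960 nM.

Compound 2 stands at the lowest number of the three, well beyond the scatter from compound 1 and from compound 3. Compound 4 `O=C([C@@H]1CCCN(S(=O)(=O)c2ccc(S(=O)(=O)N3CC[C@H](O)C3)cc2)C1)N1CCC(F)(F)CC1` differs from compound 2 in one place: 3-hydroxypyrrolidin-1-yl in place of isopropyl on a sulfonyl sulfur. Among the compounds with values here, no measured step touches this position; the only measured step, a 1.1-fold higher number from compound 1 to compound 3 (0.04 log units; within the scatter), changes the amide end and lies within the scatter. Compound 1 and compound 3 differ from compound 2 at both the sulfonyl and the amide at once, so they say nothing clean about the sulfonyl change alone. The step in this assay from compound 2 to compound 4 is therefore expected to be uncertain, guessed as a modest loss, a 5.5-fold higher number from compound 2 to compound 4 (0.74 log units; beyond the scatter). Compound 4 is estimated at 60 nM, within 10 nM to 400 nM.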

Compound 4, half-maximal inhibitory concentration: 590 nM
Estimate against measurement, compound 4: 9.8-fold (0.99 log units) below; measured number outside the range, above it.
By their numbers in this assay, from the lowest: compound 2; then compounds 4, 1 and 3 (each within the scatter of the next).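

In this assay, the position on the sulfonyl sulfur proves sensitive: with the rest of the molecule unchanged, putting 3-hydroxypyrrolidin-1-yl in place of isopropyl gives a 54-fold higher number from compound 2 to compound 4 (1.73 log units; beyond the scatter). Within the data shown here, this is the only clean reading of this position, and it shows that the isopropyl cannot be exchanged here without a large loss. Nothing available explains the size of this step.

The compounds shown leave open whether the loss goes with the ring or with its hydroxyl. An unsubstituted pyrrolidin-1-yl or a 3-methoxypyrrolidin-1-yl on the same sulfonyl sulfur would separate the two.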